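This account rests on a few compounds, and the source may have more. Where it says the series, first, only, none or still open, it means among the compounds named here.

Working notes on the series. The shared core carries a 3,4,5-trimethoxyphenyl group at one end and an aryl ketone at the other. Compound 1 `COc1cc(-c2cc(/C=C/C(=O)c3ccc(N)cc3)[nH]n2)cc(OC)c1OC` gives 1850 nM in a functional assay on HT-29 cells (Homo sapiens) for inhibition, read by sulforhodamine B assay, with a stated time of 48 h; on this read-out higher numbers stand for weaker inhibition of growth and lower numbers for stronger inhibition of growth. Compound 2 `COc1cc(-c2cc(/C=C/C(=O)c3ccc(Cl)c(Cl)c3)[nH]n2)cc(OC)c1OC` gives 1150 nM, and compound 3 `COc1ccc(-c2cc(/C=C/C(=O)c3ccc(N)cc3)[nH]n2)cc1OC` gives 2600 nM. Compound 2 therefore has the lowest number among the three, but the gap to compound 1 is within the scatter, a 1.6-fold lower number from compound 1 to compound 2 (0.21 log units; within the scatter), and only the gap to compound 3 is beyond it. The change of the aryl group on the ketone, a 1.6-fold lower number from compound 1 to compound 2 (0.21 log units; within the scatter), shifted the read-out little, and the change on the other side, a 1.4-fold higher number from compound 1 to compound 3 (0.15 log units; within the scatter), shifted it little as well.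

Compound 4 `COc1ccc(C(=O)/C=C/c2cc(-c3cc(OC)c(OC)c(OC)c3)n[nH]2)cc1` differs from compound 2 in one place: 4-methoxyphenyl in place of 3,4-dichlorophenyl on a carbonyl carbon. Going by the values given here, the one step that bears on this position, a 1.6-fold lower number from compound 1 to compound 2 (0.21 log units; within the scatter), was within the scatter, so a 4-methoxyphenyl group on the carbonyl carbon is expected to land within the same band as the 4-aminophenyl and 3,4-dichlorophenyl groups. Compound 4 is estimated at 1500 nM, with a range of 700 nM to 3500 nM; this corresponds to an expected step of a 1.3-fold higher number from compound 2 to compound 4 (0.12 log units; within the scatter), not beyond the scatter.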

Compound 4, concentration for 50% growth inhibition: 1970 nM
Estimate against measurement, compound 4: 1.3-fold (0.12 log units) below; measured number inside the range.
By their numbers in this assay, from the lowest: compounds 2, 1, 4 and 3 (each within the scatter of the next, the first and the last beyond it).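

With a third aryl group on the carbonyl carbon, the read-out in this assay still does not separate the groups at this position: the exchange of 3,4-dichlorophenyl for 4-methoxyphenyl gives (a 1.7-fold higher number from compound 2 to compound 4 (0.23 log units; within the scatter)), and methoxy in place of amino on the aromatic carbon of that ring gives (a 1.1-fold higher number from compound 1 to compound 4 (0.03 log units; within the scatter)). The 3,4-dichlorophenyl, 4-aminophenyl and 4-methoxyphenyl groups therefore form one band on the shared core, which now holds for a pair with chlorine leaving and oxygen entering, and for a pair in which a methoxy group stands in place of an amino group. No measurement at hand bears on why these groups read alike.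

Open, as far as these compounds go, is whether this band extends beyond substituted phenyl groups, for example to a carboxylic acid on the ring, a pyridine in place of the phenyl ring, or a plain alkyl chain on the carbonyl carbon. Going by these compounds alone, also open is whether hydrogen in place of methoxy on the other aryl group, seen only with the 4-aminophenyl ketone, stays within the scatter alongside the 3,4-dichlorophenyl or 4-methoxyphenyl groups.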